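A Substituent Swap on the Way to Compound 3

The compounds below may be only part of what the source reports. "The series", "measured", "known", "first", "only" and "open" are said of these compounds alone.

Compound 1 `COc1ccccc1NC(=O)c1sccc1Sc1ccc([N+](=O)[O-])cc1` and compound 2 `COc1ccccc1NC(=O)c1cc(F)ccc1Sc1ccc([N+](=O)[O-])cc1` share one core. In an ADME assay on H9 cells (Homo sapiens) for cytotoxicity, read by MTT assay, with a stated time of 7 days (on this read-out higher numbers stand for lower toxicity in this test and lower numbers for higher toxicity in this test), compound 1 gives 472000 nM, and compound 2 gives 502000 nM; compound 2 holds the highest of the two numbers, yet the gap to compound 1 is within the scatter, so the two read as alike. Compound 3 `COc1ccccc1NC(=O)c1cc(N(C)C)ccc1Sc1ccc([N+](=O)[O-])cc1` carries dimethylamino in place of fluoro on an aromatic carbon. Going by the values given here, no measured pair shows this change, so its effect is unknown. Compound 3 is expected to give 450000 nM in this assay, with a range from 200000 nM to 900000 nM. The expected step is a 1.1-fold lower number from compound 2 to compound 3 (0.05 log units; within the scatter), nothing beyond the scatter.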

Compound 3, half-maximal cytotoxic concentration: 182000 nM
For compound 3 the middle estimate is 2.5-fold (0.39 log units) above the measured one; measured number below the stated range.
By their numbers in this assay, from the lowest: compound 3; then compounds 1 and 2 (each within the scatter of the next).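

In this assay this position proves sensitive to what it carries: dimethylamino in place of fluoro on the aromatic carbon gives a 2.8-fold lower number from compound 2 to compound 3 (0.44 log units; beyond the scatter). The earlier compounds shown here offered no step at this position, and their two numbers lay within the scatter of each other. Here a lower number, which stands for higher toxicity in this test, follows the change, but nothing available bears on the reason. As far as these compounds go, whether a smaller amine, a methoxy group or a carboxylic acid at this position would read like fluoro or like dimethylamino remains open.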